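A Methyl Added to the Core of Compound 3

The compounds below may be only part of what the source reports. "The series", "measured", "known", "first", "only" and "open" are said of these compounds alone.

Measured in a functional assay on SW480 cells (Homo sapiens) for cytotoxicity, read by MTT assay, with a stated time of 72 h (a lower number here means a stronger inhibitor, a higher number a weaker inhibitor), each value a limit of the assay and not a number:
compound 1 `Cc1cc(C)nc(SCc2cc(=O)c3cc(Cl)ccc3o2)n1` gives > 25000 nM
compound 2 `Cc1nnc(Sc2c(C)oc3ccccc3c2=O)o1` gives > 50000 nM
compound 3 `Cc1cc(C)nc(SCc2cc(=O)c3ccccc3o2)n1` gives > 25000 nM

Compound 3 therefore stands at a limit of this assay, which is all that is known of it. Compound 1 sits at the same limit, as the limit of > 25000 nM in this assay, at which 2 of the 3 values shown sit, shows. Compound 2 sits at a higher limit, described by the limit of > 50000 nM in this assay, at which 1 of the 3 values shown sits. For the measured compounds named here, the only single-point step among the measured compounds, a step that the two limits leave unreadable from compound 1 to compound 3, runs between two limits and its size cannot be read, so it tells nothing about direction.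

Compound 4 `Cc1ccc2oc(CSc3nc(C)cc(C)n3)cc(=O)c2c1` differs from compound 3 by methyl in place of hydrogen on an aromatic carbon, the new group sitting meta to a fused ring and para to a fused ring on the six-membered carbon ring of the fused system. Going by the values given here, the one measured step that bears on a change at this ring, a step that the two limits leave unreadable from compound 1 to compound 3, is unreadable, so no step in this assay beyond the scatter can be foreseen in either direction.

Compound 4 is therefore expected to stay at a limit, with an estimate of 35000 nM between 12000 nM and 100000 nM, an expected step that the limit leaves unreadable from compound 3 to compound 4.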

Compound 4, half-maximal inhibitory concentration: > 25000 nM
Compound 4 ended at the assay's limit (the forecaster's own chance of this, stated with the estimate: 80%); the middle value is on the limit's open side.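

In this assay compound 4 gives > 25000 nM, a limit of the assay and not a number. Compound 1 and compound 3 also stand at limits, so the steps from either of them to compound 4 cannot be read. Going by these compounds, whether hydrogen, chloro or methyl at this place makes any difference in potency remains open.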